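The source may report more compounds than this note shows. Statements on the series, on what has been measured and on what is new or still open speak of the compounds shown alone.

Measured so far:
compound 1, `O=C(CCCc1ccccc1)Nc1nc2ccccc2c(=O)s1` — > 1000 nM
compound 2, `O=C(CCc1ccc(Cl)c(Cl)c1)Nc1nc2ccccc2c(=O)s1` — > 1000 nM

Both compounds were tested in an assay on CHO cells for displacement of a labelled ligand from adenosine receptor A3 (Homo sapiens), read by scintillation counting, with a stated time of 60 min; a higher number here means a weaker inhibitor, a lower number a stronger inhibitor. For compound 1 the result in this assay is > 1000 nM, which is a limit of the assay and not a number. For compound 2 the result in this assay is > 1000 nM, likewise a limit rather than a number. Both values sit at the limit of > 1000 nM in this assay, at which 2 of the 2 values shown sit, so compound 1 stands at that limit with no measured number to place it more closely. Among the compounds with values here, the only measured step, a step that the two limits leave unreadable from compound 1 to compound 2, cannot be read because both of its ends are limits.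

Compound 3 `CN(C(=O)CCCc1ccccc1)c1nc2ccccc2c(=O)s1` differs from compound 1 in one place: methyl in place of hydrogen on an amide-type nitrogen. Within the data shown here, no measured step touches this amide-type nitrogen, so none bears directly on the change, and the one step that exists is unreadable. With only a limit known for compound 1, the step that the limit leaves unreadable from compound 1 to compound 3 is expected to leave compound 3 at or past the same limit. Compound 3 is therefore estimated at 3000 nM, with a range from 800 nM to 20000 nM, and most likely reported again only as a limit.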

Compound 3, inhibition constant: > 1000 nM
Compound 3: only a limit was reported (the forecaster's own chance of this, stated with the estimate: 80%); the middle value lies beyond the limit too.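

The step from compound 1 to compound 3 cannot be read, because both of its ends are limits of the assay and not numbers: the limit of > 1000 nM in this assay, at which 3 of the 3 values shown sit.

The compounds shown leave open where compounds 1, 2 and 3 truly stand in this assay, and whether methyl in place of hydrogen on the amide-type nitrogen changes anything at all.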